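Chloro in Place of Amino on Two Related Cores

The source may hold more compounds than are shown below. What is called first, only, known or untested is meant among the compounds shown, and "the series" means these compounds.

In an ADME assay on L1210/0 cells (Mus musculus) for cytotoxicity, with a stated time of 48 h (on this read-out higher numbers stand for weaker inhibition and lower numbers for stronger inhibition), compound 1 `CC1(C)[C@@H](CO)CC[C@@]1(C)Cn1cnc2c(Cl)ncnc21` gives 42800 nM. Compound 2 `CC1(C)[C@@H](CO)CC[C@@]1(C)Cn1cnc2c(N)ncnc21` differs from compound 1 in one place: chloro in place of amino on an aromatic carbon. For compound 2 this assay reports only a limit, > 200000 nM. The measured step of an at least 4.6-fold lower number from compound 2 to compound 1 (0.66 log units; beyond the scatter) is thus at least modest. Compound 3 `CC1(C)C(CO)CC1Cn1nnc2c(N)nc(N)nc21` stands on another core; how its core differs from that of compound 2 is not broken down here. For compound 3 this assay likewise reports only a limit, > 200000 nM. That value sits at the limit of > 200000 nM in this assay, at which 2 of the 3 values shown sit. Compound 4 `CC1(C)C(CO)CC1Cn1nnc2c(Cl)nc(N)nc21` is not yet measured, and it carries the same kind of change relative to compound 3: chloro in place of amino on an aromatic carbon. Around the place, the change on compound 3 is also meta to an amino group (1 heavy atom), which the change on compound 2 is not. Beside the earlier step of an at least 4.6-fold lower number from compound 2 to compound 1 (0.66 log units; beyond the scatter), the step of an at least 2.8-fold lower number from compound 3 to compound 4 (0.45 log units; beyond the scatter) is expected in this assay, resting on that earlier step and on the same kind of change. Compound 4 is therefore estimated at 70000 nM in this assay, expected between 15000 nM and 200000 nM, with a limit again possible.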

Compound 4, half-maximal inhibitory concentration: > 200000 nM
Compound 4: only a limit was reported; the forecaster's own chance of this, stated with the estimate: 40%; at least 2.8-fold (0.45 log units) between middle value and limit.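

In this assay compound 4 gives only a limit, > 200000 nM, and since compound 3 is also reported only as a limit, no step between the two can be read: the limit of > 200000 nM in this assay, at which 3 of the 4 values shown sit.

The compounds shown leave open whether chloro in place of amino on an aromatic carbon changes the number at all on the core of compound 3.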